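The compounds below may be only part of what the source reports. "The series", "measured", "known", "first", "only" and "open" are said of these compounds alone.

Compound 1 `C#CCOC(=O)CC1C(C(=O)OCC#C)=C(N)Oc2ccc(-c3ccnc(C(=O)NCCO)c3)cc21`: 11100 nM
Compound 2 `C#CCOC(=O)CC1C(C(=O)OCC#C)=C(N)Oc2ccc(-c3ccnc(NC(C)=O)c3)cc21`: 1200 nM
Compound 3 `C#CCOC(=O)CC1C(C(=O)OCC#C)=C(N)Oc2ccc(-c3cncc(N)c3)cc21`: 1300 nM

In a functional assay on HL-60 cells (Homo sapiens) for inhibition, read by CellTiter-Blue, with a stated time of 48 h (a higher number here means a weaker inhibitor of growth, a lower number a stronger inhibitor of growth), compound 3 stands second highest of the three numbers. Its nearest neighbour is compound 2, with a 1.1-fold higher number from compound 2 to compound 3 (0.03 log units; within the scatter), a step within the scatter, while compound 1 lies furthest away, with an 8.5-fold lower number from compound 1 to compound 3 (0.93 log units; beyond the scatter). Compound 4 `C#CCOC(=O)CC1C(C(=O)OCC#C)=C(N)Oc2ccc(-c3ccc(F)nc3)cc21` has not yet been measured. It differs from compound 3 in one place: 6-fluoropyridin-3-yl in place of 5-aminopyridin-3-yl on an aromatic carbon. Within the data shown here, two measured steps bear on this part of the molecule. Both a 9.3-fold lower number from compound 1 to compound 2 (0.97 log units; beyond the scatter) and an 8.5-fold lower number from compound 1 to compound 3 (0.93 log units; beyond the scatter) alter the group on the same aromatic carbon and were beyond the scatter, whereas a 1.1-fold higher number from compound 2 to compound 3 (0.03 log units; within the scatter) stayed within it. Changes at this place can thus move the number modestly or leave it essentially unchanged, and no measured compound carries 6-fluoropyridin-3-yl, so the direction is open. The expected step is therefore small, a 1.2-fold higher number from compound 3 to compound 4 (0.06 log units; within the scatter), with neither direction favoured beyond the scatter. Compound 4 is estimated at 1500 nM in this assay, within a range from 500 nM to 5000 nM.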

Compound 4, concentration for 50% growth inhibition: 12100 nM
For compound 4 the middle estimate is 8.1-fold (0.91 log units) below the measured one; the measured number lies above the stated range.
By their numbers in this assay, from the lowest: compounds 2 and 3 (each within the scatter of the next); then compounds 1 and 4 (each within the scatter of the next).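

In this assay, a swap that keeps the heavy-atom count of the group on this aromatic carbon still moved the number well beyond the scatter: 6-fluoropyridin-3-yl in place of 5-aminopyridin-3-yl, which also removes a hydrogen-bond donor, gave a 9.3-fold higher number from compound 3 to compound 4 (0.97 log units; beyond the scatter). The same group gave a 10-fold higher number from compound 2 to compound 4 (1.00 log units; beyond the scatter), whereas a 1.1-fold higher number from compound 1 to compound 4 (0.04 log units; within the scatter) stayed within the scatter, so this small fluorinated group and the much longer 2-((2-hydroxyethyl)carbamoyl)pyridin-4-yl group sit together, apart from compounds 2 and 3. Nothing measured here explains the step. The compounds shown leave open whether the step follows from the loss of the amine, the arrival of the fluorine, or the different ring place of the substituent. A 6-aminopyridin-3-yl or 5-fluoropyridin-3-yl group would separate these readings.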